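The source may report more compounds than this note shows. Statements on the series, on what has been measured and on what is new or still open speak of the compounds shown alone.

In an assay on Cortex with Norepinephrine transporter (Rattus norvegicus) as the target (a higher number here means a weaker inhibitor, a lower number a stronger inhibitor), compound 1 `C=CCOC[C@H]1CN(C)CC[C@@H]1c1ccc(Cl)cc1` gives 20 nM and compound 2 `CN1CC[C@H](c2ccc(Cl)cc2)[C@@H](CCC(=O)O)C1` gives 425 nM; compound 2 stands highest of the two numbers shown. Compound 3 `COC(=O)/C=C/[C@H]1CN(C)CC[C@@H]1c1ccc(Cl)cc1` is unmeasured. The change is 2-(methoxycarbonyl)ethenyl in place of 2-carboxyethyl on a saturated ring carbon. Going by the values given here, the one measured step that bears on it, a 21-fold higher number from compound 1 to compound 2 (1.33 log units; beyond the scatter), was large and accompanied the arrival of the carboxylic acid. Compound 3 carries 0 hydrogen-bond donors, as compound 1 does, so a step back down is expected, though not the full return. Compound 3 is therefore estimated at 70 nM in this assay, range 15 nM to 300 nM, a step of a 6.1-fold lower number from compound 2 to compound 3 (0.78 log units; beyond the scatter).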

Compound 3, inhibition constant: 272 nM
Estimate against measurement, compound 3: 3.9-fold (0.59 log units) below; measured number inside the range.
By their numbers in this assay, from the lowest: compound 1; then compounds 3 and 2 (each within the scatter of the next).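

In this assay the step of a 1.6-fold lower number from compound 2 to compound 3 (0.19 log units; within the scatter) stays within the scatter, so 2-(methoxycarbonyl)ethenyl, without a hydrogen-bond donor, and 2-carboxyethyl cannot be told apart on this saturated ring carbon. The step of a 14-fold higher number from compound 1 to compound 3 (1.13 log units; beyond the scatter) is large, so sharing the absence of a hydrogen-bond donor with compound 1 does not bring compound 3 close to it. No measurement at hand explains this result. Open, on these data alone, is how a saturated methyl ester chain, an amide or a longer ether chain would read at this position.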